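Cytotoxicity in a phenyl ester series: methyl for bromo

The compounds below may be only part of what the source reports. "The series", "measured", "known", "first", "only" and "open" are said of these compounds alone.

Measured numbers in an ADME assay on cells (T-cell, Mus musculus, strain BALB/c) for cytotoxicity, read by MTT assay, with a stated time of 48 h; a lower number here means that less compound is tolerated, a higher number that more compound is tolerated:
- compound 1 `COC(=O)c1cc(O)ccc1OC(=O)COc1cc(O)c2c(=O)cc(-c3ccccc3)oc2c1` gives 263000 nM
- compound 2 `COC(=O)c1cccc(C)c1OC(=O)COc1cc(O)c2c(=O)cc(-c3ccccc3)oc2c1` gives 299000 nM
- compound 3 `COC(=O)c1c(Br)cccc1OC(=O)COc1cc(O)c2c(=O)cc(-c3ccccc3)oc2c1` gives 388000 nM

All three share one core and differ only in the aryl group on the oxygen next to the carbonyl. Compound 3 carries the largest of the three numbers, but the steps leading to it are small: a 1.5-fold higher number from compound 1 to compound 3 (0.17 log units; within the scatter) and a 1.3-fold higher number from compound 2 to compound 3 (0.11 log units; within the scatter). Likewise a 1.1-fold higher number from compound 1 to compound 2 (0.06 log units; within the scatter). Nothing in this set moves beyond the scatter.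

Compound 4 `COC(=O)c1c(C)cccc1OC(=O)COc1cc(O)c2c(=O)cc(-c3ccccc3)oc2c1` is not yet measured. It differs from compound 3 by methyl in place of bromo on an aromatic carbon. Within the data shown here, the steps that bear on this are those that already exchanged the substituent pattern of the same aryl group, a 1.3-fold higher number from compound 2 to compound 3 (0.11 log units; within the scatter) and a 1.5-fold higher number from compound 1 to compound 3 (0.17 log units; within the scatter), and both stayed within the scatter. Compound 2, which also carries a methyl on this ring, gives 299000 nM, close to compound 3. The expected step is therefore a 1.2-fold lower number from compound 3 to compound 4 (0.07 log units; within the scatter), that is, none beyond the scatter. Compound 4 is estimated to give 330000 nM in this assay, with a range from 200000 nM to 520000 nM.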

Compound 4, half-maximal cytotoxic concentration: 298000 nM
Estimate against measurement, compound 4: 1.1-fold (0.04 log units) above; measured number inside the range.
By their numbers in this assay, from the lowest: compounds 1, 4, 2 and 3 (each within the scatter of the next).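

In this assay, methyl in place of bromo on the aromatic carbon ortho to a methoxycarbonyl group gives a 1.3-fold lower number from compound 3 to compound 4 (0.11 log units; within the scatter) and so shows that, between these two groups, this position carries no step beyond the scatter. Moving the methyl to another place on the aryl group is no more telling: a 1.0-fold lower number from compound 2 to compound 4 (0.00 log units; within the scatter) is the step for that exchange. The aryl group with a hydroxyl instead gives a 1.1-fold higher number from compound 1 to compound 4 (0.05 log units; within the scatter) and thus adds a third small step, so all four compounds remain within the scatter of the next.

Nothing measured here gives a reason for these small steps. From the compounds shown here alone, whether an amine, a carboxylic acid or a longer chain at this position would produce a step beyond the scatter remains open.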